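Fluorine placement on the aryl ring in the isoxazole-pyrazole series

A few compounds are considered here, and "the series" means these few. Any claim that something is new, unique, unknown or untested is made for them only; others in the source may bear on it.

Measured so far:
compound 1, `Clc1ccccc1-c1cc(-c2cnn(C3CCNCC3)c2)on1`, 120 nM
compound 2, `Fc1cccc(Cl)c1-c1cc(-c2cnn(C3CCNCC3)c2)on1`, 48 nM

In an assay on isolated protein for positive allosteric modulation of Neuronal acetylcholine receptor; alpha4/beta2 (Homo sapiens) (on this read-out lower numbers stand for an effect already at smaller amounts and higher numbers for an effect only at larger amounts of compound), compound 2 stands lowest of the two numbers shown; its nearest neighbour is compound 1, which sits a modest way higher, and the step of a 2.5-fold lower number from compound 1 to compound 2 (0.40 log units; beyond the scatter) lies beyond the scatter. Compound 3, `Fc1ccc(Cl)c(-c2cc(-c3cnn(C4CCNCC4)c3)on2)c1`, has not been measured. It differs from compound 2 in one place: 2-chloro-5-fluorophenyl in place of 2-chloro-6-fluorophenyl on an aromatic carbon, the two having the same atoms joined differently.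

Among the compounds with values here, no measured step bears directly on this change. Within the data shown here, the one step available, a 2.5-fold lower number from compound 1 to compound 2 (0.40 log units; beyond the scatter), concerns only whether the fluorine is present at all, not where it sits, so it gives limited guidance. Since compound 1 without the fluorine gives 120 nM and compound 2 gives 48 nM, the expectation for compound 3 is a number in that neighbourhood, most likely without a step beyond the scatter, or at most a small rise, a 1.7-fold higher number from compound 2 to compound 3 (0.22 log units; within the scatter). The estimate for compound 3 in this assay is therefore 80 nM, with a range from 30 nM to 220 nM.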

Compound 3, half-maximal effective concentration: 270 nM
For compound 3 the middle estimate is 3.4-fold (0.53 log units) below the measured one, and the stated range ends below it.
By their numbers in this assay, from the lowest: compound 2; then compound 1; then compound 3.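

In this assay, the step from 2-chloro-6-fluorophenyl to 2-chloro-5-fluorophenyl is a 5.6-fold higher number from compound 2 to compound 3 (0.75 log units; beyond the scatter), so with the same atoms present, where the fluorine sits on this aryl ring matters and not merely whether it is there. The fluoro-for-hydrogen exchange also has no single direction in this series: set against a 2.5-fold lower number from compound 1 to compound 2 (0.40 log units; beyond the scatter), the other placement gives a 2.3-fold higher number from compound 1 to compound 3 (0.35 log units; beyond the scatter), with both steps beyond the scatter but opposite in sign, so the earlier step cannot be read as a general effect of adding fluorine to the ring. Nothing available here accounts for the difference between the two placements.

The three compounds leave open whether this dependence on placement is specific to fluorine or would also appear with a methyl or methoxy group in its place on the 2-chloro-substituted ring. They also leave open whether the order seen here would hold with a second chlorine in place of the fluorine, or with the same aryl groups on a changed version of the shared core.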